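The source may hold more compounds than are shown below. What is called first, only, known or untested is meant among the compounds shown, and "the series" means these compounds.

Working notes on two measured analogues and one awaiting measurement. Compound 1 `NCCCOc1ccc(CNc2nc3ccc(Oc4ccc(O)cc4)cc3s2)cc1` and compound 2 `N=C(N)NCCCOc1ccc(CNc2nc3ccc(Oc4ccc(C(F)(F)F)cc4)cc3s2)cc1` share a core and differ in two places at once. In an assay on cells for inhibition of Voltage-dependent T-type calcium channel subunit alpha-1H (Homo sapiens), read by FLIPR and calcium flux, with stated times of 600 s and 300 s (on this read-out higher numbers stand for weaker inhibition and lower numbers for stronger inhibition), compound 1 gives 300000 nM. In this assay compound 2 gives 195000 nM; the gap between compound 2 and compound 1 lies within the usual scatter, so the two numbers are not separated. Compound 3 `N=C(N)NCCCOc1ccc(CNc2nc3ccc(Oc4ccc(O)cc4)cc3s2)cc1` differs from compound 2 in one place only: hydroxy in place of trifluoromethyl on an aromatic carbon. Among the compounds with values here, no single-change step between measured compounds is available, and compound 1 carries the hydroxy together with a different chain, so it gives no direct reading of this change. The expectation is that the step from compound 2 to compound 3 in this assay is small, a 1.3-fold higher number from compound 2 to compound 3 (0.11 log units; within the scatter), not beyond the scatter in either direction. Compound 3 is therefore estimated at 250000 nM, with a range from 100000 nM to 600000 nM.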

Compound 3, half-maximal inhibitory concentration: 319000 nM
Compound 3: the middle estimate sits 1.3-fold (0.11 log units) below what was measured, and the stated range covers the measured number.
By their numbers in this assay, from the lowest: compounds 2, 1 and 3 (each within the scatter of the next).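

The two single-change steps now separate what compound 1 and compound 2 left combined: in this assay, hydroxy in place of trifluoromethyl on an aromatic carbon, para to a large group, gives (a step of a 1.6-fold higher number from compound 2 to compound 3 (0.21 log units; within the scatter)), which does not separate the two groups at this position. On the chain, a group of 3 heavy atoms in place of a hydrogen atom on an amine nitrogen gives (a step of a 1.1-fold higher number from compound 1 to compound 3 (0.03 log units; within the scatter)), so this change is not separated from the scatter either. No measurement bears on why neither step goes beyond the scatter.

Going by these compounds, it remains open whether another group at this aromatic carbon, such as an amine or a carboxylic acid, would give a step beyond the scatter. On these data alone, a longer chain in place of the present one also remains untested in these compounds.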